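Aryl ether variation on the bicyclic amine series

The compounds below may be only part of what the source reports. "The series", "measured", "known", "first", "only" and "open" are said of these compounds alone.

Measured so far:
compound 1 `C1=C(c2cncc(OCc3ccccc3)c2)CC2CNCC1C2` 44 nM
compound 2 `Clc1ccc(C2=CC3CNCC(C2)C3)cn1` 6.2 nM
compound 3 `C1=C(c2cccnc2)C[C@H]2CNC[C@@H]1C2` 4 nM

In an in vitro assay on SH-SY5Y cells for displacement of a labelled ligand from Neuronal acetylcholine receptor; alpha3/beta4 (Homo sapiens) (a higher number here means a weaker inhibitor, a lower number a stronger inhibitor), compound 1 gives the highest of the three numbers; compound 2 and compound 3 both sit lower by margins beyond the scatter, so compound 1 is the weakest inhibitor of this set. Compound 4 `Clc1ccc(Oc2cncc(C3=CC4CNCC(C3)C4)c2)cc1` keeps the ether of compound 1 but swaps the group on its oxygen: 4-chlorophenyl in place of benzyl on an oxygen on an aromatic ring. The two groups match in count and ring type, so no large step is expected; the change from compound 1 to compound 4 in this assay is expected to be a 1.5-fold lower number from compound 1 to compound 4 (0.17 log units; within the scatter), within the scatter or at most slightly toward a lower number. Compound 4 is therefore estimated at 30 nM, with a range from 8 nM to 120 nM.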

Compound 4, inhibition constant: 40 nM
Compound 4: the middle estimate sits 1.3-fold (0.12 log units) below what was measured, within the range that was stated.
By their numbers in this assay, from the lowest: compounds 3 and 2 (each within the scatter of the next); then compounds 4 and 1 (each within the scatter of the next).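

In this assay the change to 4-chlorophenyl in place of benzyl on an oxygen on an aromatic ring gives a 1.1-fold lower number from compound 1 to compound 4 (0.04 log units; within the scatter) and so stays within the scatter. For the compounds shown here, this position therefore tolerates this exchange of one carbon-only aromatic group for another, which the earlier compounds could not show. No measurement bears on the reason for this result.

Still open, from the compounds shown here alone, is whether plain phenyl, without the chlorine, would read the same on this oxygen. Also open, going by these compounds, is how an amine, a carboxylic acid or a longer chain there would read.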